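The compounds below may be only part of what the source reports. "The series", "measured", "known", "first", "only" and "open" are said of these compounds alone.

Measured compounds in a functional assay on HT-29 cells (Homo sapiens) for antiproliferative activity, read by MTT assay, with a stated time of 24 h; a lower number here means a stronger inhibitor, a higher number a weaker inhibitor:
- Compound 1 `COc1cc(OC)c(OC)cc1/C=C/C(=O)c1ccc(OC)c2c1OC(C)(C)C=C2` gives a limit rather than a number, > 10000 nM.
- Compound 2 `COc1ccc(C(=O)/C=C/c2cccc(F)c2)c2c1C=CC(C)(C)O2` likewise gives only a limit, > 10000 nM.
- Compound 3 `COc1ccc(C(=O)/C=C/c2ccc3ccccc3n2)c2c1C=CC(C)(C)O2` gives a measured value, 3790 nM.

Compound 2 therefore stands at the limit in this assay, and it is not alone there: the limit of > 10000 nM in this assay, at which 2 of the 3 values shown sit. Only compound 3 returns a number at all, and no pair of these compounds differs in a single place, so no measured step can be drawn between them.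

Compound 4 `COc1ccc(C(=O)/C=C/c2ccccc2Cl)c2c1C=CC(C)(C)O2` is the one still to be measured. It differs from compound 2 in one place: 2-chlorophenyl in place of 3-fluorophenyl on a double-bonded chain carbon bound to a double-bonded chain carbon. Going by the values given here, with compound 2 sitting at the limit, a step to compound 4 can only be expected either as no change beyond the scatter or as a move to a measurable value, and there is nothing among the measured compounds that points to the latter. The expected step from compound 2 to compound 4 is therefore a step that the limit leaves unreadable from compound 2 to compound 4, essentially none. Compound 4 is expected to give about 12000 nM in this assay, within 4000 nM to 40000 nM, most likely again as a limit only.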

Compound 4, half-maximal inhibitory concentration: > 10000 nM
Compound 4 was reported as a limit (the forecaster's own chance of this, stated with the estimate: 70%); the middle value is on the limit's open side.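

Compound 2 and compound 4 both stand only as limits in this assay, so no step can be read between them: the limit of > 10000 nM in this assay, at which 3 of the 4 values shown sit.

The compounds shown leave open how far 2-chlorophenyl and 3-fluorophenyl differ in this assay, as neither compound returns a number.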